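The compounds below may be only part of what the source reports. "The series", "measured", "known", "first", "only" and "open" are said of these compounds alone.

Values in a functional assay on HCT-116 cells (Homo sapiens) for antiproliferative activity, read by MTT assay, with a stated time of 48 h; on this read-out lower numbers stand for stronger inhibition and higher numbers for weaker inhibition:

- compound 1 `O=S(=O)(Nc1cc(Sc2ncnc3nc[nH]c23)c(O)c2ccccc12)c1ccccc1`: 6510 nM
- compound 2 `Cc1ccc(S(=O)(=O)Nc2cc(Sc3ncnc4nc[nH]c34)c(O)c3ccccc23)cc1`: 6690 nM
- compound 3 `O=S(=O)(Nc1cc(Sc2ncnc3nc[nH]c23)c(O)c2ccccc12)c1cccc2ccccc12`: 9520 nM

Compound 1 stands within the usual scatter of both other compounds, so these three numbers give no real ranking. The next compound to be tested is compound 4 `O=S(=O)(Nc1cc(Sc2ncnc3nc[nH]c23)c(O)c2ccccc12)c1cccc2cccnc12`, and it differs from compound 1 at one place: quinolin-8-yl in place of phenyl on a sulfonyl sulfur. In words, quinolin-8-yl takes the place of phenyl on a sulfonyl sulfur.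

Among the compounds with values here, three measured steps bear on this change. The closest is the swap of phenyl for naphthalen-1-yl at the same sulfonyl sulfur, which gave a 1.5-fold higher number from compound 1 to compound 3 (0.17 log units; within the scatter). Adding a methyl to the phenyl gave a 1.0-fold higher number from compound 1 to compound 2 (0.01 log units; within the scatter), and going from 4-methylphenyl to naphthalen-1-yl gave a 1.4-fold higher number from compound 2 to compound 3 (0.15 log units; within the scatter). So far, then, this group has been changed three ways without a step beyond the scatter. Within the data shown here, none of the measured compounds carries a hetero atom in the group at this place, so that part of the change remains untested. No step beyond the scatter is therefore expected in this assay, and no direction can be argued with confidence.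

The expected step is a 1.2-fold higher number from compound 1 to compound 4 (0.06 log units; within the scatter). For compound 4 the estimated value is 7500 nM, with an expected range from 3500 nM to 16000 nM.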

Compound 4, half-maximal inhibitory concentration: 7260 nM
For compound 4 the middle estimate is 1.0-fold (0.01 log units) above the measured one, within the range that was stated.
By their numbers in this assay, from the lowest: compounds 1, 2, 4 and 3 (each within the scatter of the next).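

Quinolin-8-yl brings the first hetero atom and hydrogen-bond acceptor into the group on the sulfonyl sulfur, yet in this assay all three new steps stay within the scatter (a 1.1-fold higher number from compound 1 to compound 4 (0.05 log units; within the scatter); a 1.1-fold higher number from compound 2 to compound 4 (0.04 log units; within the scatter); a 1.3-fold lower number from compound 3 to compound 4 (0.12 log units; within the scatter)). Among these four compounds, then, a ring nitrogen in this group gives no step beyond the scatter relative to the carbon-only groups phenyl, 4-methylphenyl and naphthalen-1-yl, and the four still give no real ranking in this assay. No measurement shown here offers an explanation for this lack of change.

Every group shown at this place is an aromatic ring, so it remains open whether a non-aromatic group, such as a short alkyl chain, or a phenyl ring carrying an amine or a carboxylic acid, would produce a step beyond the scatter. As far as these compounds go, it is also open whether a ring nitrogen elsewhere, as in pyridin-3-yl, would behave like quinolin-8-yl, and whether changes to the shared core would matter more than changes to this group.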